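A few compounds are considered here, and "the series" means these few. Any claim that something is new, unique, unknown or untested is made for them only; others in the source may bear on it.

Compound 2 `Nc1ccc(S(=O)(=O)N2CCN(c3ncc(C(O)(C(F)(F)F)C(F)(F)F)cc3-c3ccoc3)CC2)cn1` sits second highest of the three numbers in an ADME assay (liver) for metabolic stability, with Liver microsome (Rattus norvegicus) as the target, using microsomes and NADPH, with a stated time of 30 min, tested at 1 uM (on this read-out higher numbers stand for fast clearance and lower numbers for slow clearance), giving 57 mL.min-1.g-1. Its companions are compound 1 `Nc1ccc(S(=O)(=O)N2CCN(c3ncc(C(O)(C(F)(F)F)C(F)(F)F)cc3C#CCO)CC2)cn1`, which gives 65 mL.min-1.g-1, and compound 3 `Nc1ccc(S(=O)(=O)N2CCN(c3ncc(C(O)(C(F)(F)F)C(F)(F)F)cc3-c3ccncc3)CC2)cn1`, which gives 31 mL.min-1.g-1. The move a 1.1-fold lower number from compound 1 to compound 2 (0.06 log units; within the scatter) and the move a 1.8-fold lower number from compound 2 to compound 3 (0.26 log units; within the scatter) both stay within the scatter, and only a 2.1-fold lower number from compound 1 to compound 3 (0.32 log units; beyond the scatter) reaches beyond it. Compound 4 `Nc1ccc(S(=O)(=O)N2CCN(c3ncc(C(O)(C(F)(F)F)C(F)(F)F)cc3-c3ccc4[nH]ncc4c3)CC2)cn1` arises from compound 2 by the change (1H-indazol-5-yl in place of furan-3-yl on an aromatic carbon). Among the compounds with values here, the nearest precedent is the exchange of furan-3-yl for another aromatic ring, pyridin-4-yl, which stayed within the scatter, so at most a small lowering is foreseen here. Compound 4 is therefore expected to give 45 mL.min-1.g-1, in a range from 25 mL.min-1.g-1 to 80 mL.min-1.g-1, which would be a step of a 1.3-fold lower number from compound 2 to compound 4 (0.10 log units; within the scatter).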

Compound 4, intrinsic clearance in microsomes: 88 mL.min-1.g-1
For compound 4 the middle estimate is 2.0-fold (0.29 log units) below the measured one, outside the stated range (above it).
By their numbers in this assay, from the lowest: compounds 3, 2, 1 and 4 (each within the scatter of the next, the first and the last beyond it).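

In this assay, the 1H-indazol-5-yl group, with its second ring, gives no step beyond the scatter from either furan-3-yl, a 1.5-fold higher number from compound 2 to compound 4 (0.19 log units; within the scatter), or 3-hydroxyprop-1-yn-1-yl, a 1.4-fold higher number from compound 1 to compound 4 (0.13 log units; within the scatter). The new compound does, however, separate from the pyridin-4-yl analogue, a 2.8-fold higher number from compound 3 to compound 4 (0.45 log units; beyond the scatter), so aromatic replacements at this position need not lower the number. No supporting measurement bears on why these groups differ. Still open, from the compounds shown here alone, is whether a plain phenyl ring, or one carrying a carboxylic acid or an aminomethyl group, would fall nearer compound 3 or compound 4.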